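Isopropyl gives way to oxan-4-yl

This account rests on a few compounds, and the source may have more. Where it says the series, first, only, none or still open, it means among the compounds named here.

Within the data shown here, in a functional assay on HCC827 cells (Homo sapiens) for antiproliferative activity, read by MTT assay, with a stated time of 72 h (on this read-out lower numbers stand for stronger inhibition and higher numbers for weaker inhibition), compound 3 `CC(C)n1c([S+]([O-])c2ccccc2)nc2cnc(Nc3ccc(N4CCN(C)CC4)cc3)nc21` gives 215 nM, the lowest of the three numbers so far. Compound 4 `CN1CCN(c2ccc(Nc3ncc4nc([S+]([O-])c5ccccc5)n(C5CCOCC5)c4n3)cc2)CC1` keeps the rest of compound 3 but has oxan-4-yl in place of isopropyl on an aromatic nitrogen. Among the measured compounds shown here, no measured step isolates this swap. Compound 1 `CN1CCC(Oc2ccc(Nc3ncc4nc([S+]([O-])c5ccccc5)n(C5CCOCC5)c4n3)cc2)CC1` gives 853 nM and compound 2 `CN(C)CCN(C)c1ccc(Nc2ncc3nc([S+]([O-])c4ccccc4)n(C4CCOCC4)c3n2)cc1` gives 1330 nM. Both carry oxan-4-yl, but each also differs from compound 3 in another group. For the measured compounds named here, the one measured step, a 1.6-fold higher number from compound 1 to compound 2 (0.19 log units; within the scatter), lies within the scatter and concerns only that other group. A moderate rise is therefore expected, an estimated 2.3-fold higher number from compound 3 to compound 4 (0.37 log units; beyond the scatter). For compound 4 the estimated value is 500 nM, with an expected range of 170 nM to 1300 nM.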

Compound 4, half-maximal inhibitory concentration: 411 nM
The estimate for compound 4 lay 1.2-fold (0.09 log units) above the measured number; the range from low to high includes it.
By their numbers in this assay, from the lowest: compounds 3 and 4 (each within the scatter of the next); then compounds 1 and 2 (each within the scatter of the next).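

In this assay, the direct swap on this aromatic nitrogen gives a 1.9-fold higher number from compound 3 to compound 4 (0.28 log units; within the scatter), so on this read-out oxan-4-yl and isopropyl cannot be told apart, despite the added ring and oxygen. With oxan-4-yl held fixed, the group on the aromatic carbon does separate compounds: 4-methylpiperazin-1-yl gives a 3.2-fold lower number from compound 2 to compound 4 (0.51 log units; beyond the scatter) and a 2.1-fold lower number from compound 1 to compound 4 (0.32 log units; beyond the scatter). Nothing available explains these steps. Still open, as far as these compounds go, is how a methyl, a cyclopropyl or a 2-hydroxyethyl chain on this nitrogen would read. Also open, from the compounds shown here alone, is whether a piperidine on the aromatic carbon would match 4-methylpiperazin-1-yl.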